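The compounds below may be only part of what the source reports. "The series", "measured", "known", "first", "only" and "open" are said of these compounds alone.

Compound 1 `CN1CCN(c2nc(-c3cccc(O)c3)nc3[nH]cnc23)CC1` carries a 3-hydroxyphenyl group on the shared core; in an assay on cells for displacement of a labelled ligand from adenosine receptor A3 (Homo sapiens), read by scintillation counting and radioligand binding, with a stated time of 180 min, tested at 10 uM (a lower number here means less inhibition, a higher number more inhibition at the concentration tested (going by the name of the read-out)), compound 1 reaches > 80%, which is a limit of the assay rather than a number. Compound 2 `Clc1ccc(Cl)c(-c2nc(N3CCCCC3)c3nc[nH]c3n2)c1` likewise reaches > 80% in this assay, again a limit. Among the measured compounds shown here, compound 3 `CN1CCN(c2nc(-c3ccc(O)cc3)nc3[nH]cnc23)CC1`, with 4-hydroxyphenyl in place of 3-hydroxyphenyl, gives 48% in this assay, the only plain number among the three. For the measured compounds named here, the one measured step, a number at least 32 percentage points lower from compound 1 to compound 3 (beyond the scatter), shows that exchanging 3-hydroxyphenyl for 4-hydroxyphenyl costs a large share of the inhibition.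

Compound 4 `CN1CCN(c2nc(-c3cc(Cl)ccc3Cl)nc3[nH]cnc23)CC1` differs from compound 3 in that place: 2,5-dichlorophenyl in place of 4-hydroxyphenyl on an aromatic carbon. The step from compound 1 to compound 3 bears on this change only in so far as it shows that the group on this aromatic carbon can shift the read-out by a large amount. Compound 2, which carries the same 2,5-dichlorophenyl group though it differs from compound 4 elsewhere as well, sits at a limit. Moreover the limit of > 80% in this assay, at which 2 of the 3 values shown sit, marks where two of the three values already stand. The step of a number 30 percentage points higher from compound 3 to compound 4 (beyond the scatter) is therefore expected to run upward, back toward that limit. For compound 4 a value of 78% is estimated, within the range 55% to 95%.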

Compound 4, a percentage reported as inhibition, at one concentration (the size of the read-out at that concentration, not a potency): > 80%
Compound 4: a limit, no number; the forecaster's own chance of this, stated with the estimate: 50%; middle value at least 2 percentage points away from the limit.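

At this aromatic carbon, between two ring nitrogen atoms, this assay records a number at least 32 percentage points higher from compound 3 to compound 4 (beyond the scatter) when 2,5-dichlorophenyl enters in place of 4-hydroxyphenyl, with the 4-methylpiperazin-1-yl group unchanged. Among the compounds shown here, the earlier step showed only that exchanging one hydroxyphenyl group for the other lowers the read-out; this one shows that the aryl group here needs no hydroxyl for high inhibition, since a group with 0 hydrogen-bond donors and 0 hydrogen-bond acceptors serves. The steps from compound 2 to compound 4 and from compound 1 to compound 4 cannot be read, so the effects of the piperidin-1-yl group and of the 3-hydroxyphenyl group relative to compound 4 stay unresolved, and most of the values now sit at one bound: the limit of > 80% in this assay, at which 3 of the 4 values shown sit.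

The compounds shown leave open whether both chlorine atoms of the 2,5-dichlorophenyl group are needed, or whether a single chlorine would do as well. They also leave open how a phenyl group carrying an amine or a carboxylic acid would behave at this aromatic carbon.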